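Methoxy on the styryl arene of a pyranone pair

The source may report more compounds than this note shows. Statements on the series, on what has been measured and on what is new or still open speak of the compounds shown alone.

Measured so far in a functional assay on HT-29 cells (Homo sapiens) for inhibition, read by sulforhodamine B assay, with a stated time of 48 h; a higher number here means a weaker inhibitor of growth, a lower number a stronger inhibitor of growth:
compound 1 `O=C1C=COC(/C=C/c2ccccc2)C1` gives 124 uM
compound 2 `COc1ccc(/C=C/C2CC(=O)C=CO2)cc1` gives 204 uM
compound 3 `O=c1ccoc(/C=C/c2ccccc2)c1` gives 344 uM

Compound 3 has the highest of the three numbers. Against compound 1 the gap is beyond the scatter, so compound 3 is the weaker inhibitor of growth of that pair; against compound 2 the gap lies within the scatter, and no order can be read between them.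

The unmeasured compound 4 `COc1ccc(/C=C/c2cc(=O)cco2)cc1` differs from compound 3 by methoxy in place of hydrogen on an aromatic carbon.

Among the measured compounds shown here, one measured step bears on this change: the same exchange on the core of compound 1 gave a 1.6-fold higher number from compound 1 to compound 2 (0.22 log units; within the scatter), which did not leave the scatter. The core of compound 3 differs from that of compound 1, so the transfer is not secure, but nothing in the numbers points to a large effect of the methoxy. The expectation for compound 4 in this assay is therefore a step of about the same size and direction, or none beyond the scatter, shown as a 1.4-fold higher number from compound 3 to compound 4 (0.14 log units; within the scatter).

Compound 4 is thus estimated at 480 uM, with a range from 200 uM to 1100 uM, the upper part of which approaches where this assay may report only a limit.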

Compound 4, concentration for growth inhibition (reported as GI): 379 uM
Compound 4: the middle estimate sits 1.3-fold (0.10 log units) above what was measured, within the range that was stated.
By their numbers in this assay, from the lowest: compounds 1, 2, 3 and 4 (each within the scatter of the next, the first and the last beyond it).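

In this assay, methoxy in place of hydrogen on the aromatic carbon para to a group of 9 heavy atoms now has a second reading, on the core of compound 3, and gives a 1.1-fold higher number from compound 3 to compound 4 (0.04 log units; within the scatter). The earlier pair alone could not show whether a step within the scatter was particular to the core of compound 1; the change now stays within the scatter on both cores, and the two steps agree with each other: the same change on two cores in this assay, a 1.6-fold higher number (0.22 log units; within the scatter) from compound 1 to compound 2 and a 1.1-fold higher number (0.04 log units; within the scatter) from compound 3 to compound 4, 1.5-fold (0.17 log units) apart, within the scatter of two such steps. Across these two pairs, the exchange of hydrogen for methoxy at this position gives no readable change in growth inhibition, and compound 4 stands at 379 uM, within the scatter of its hydrogen partner.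

With only hydrogen and methoxy shown at this position, it remains open whether another group there, such as an amine, a hydroxyl or a carboxylic acid, would give a step beyond the scatter on either core. Also open, going by these compounds, is whether methoxy on another carbon of the same aromatic ring would behave as it does here.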